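The compounds below may be only part of what the source reports. "The series", "measured", "known", "first", "only" and "open" are said of these compounds alone.

Measured so far:
Compound 1, `CC(NC(=O)/C=C/c1ccc(C(C)(C)C)cc1)c1ccc(NS(C)(=O)=O)c(F)c1`; in an assay on CHO cells for displacement of a labelled ligand from transient receptor potential cation channel subfamily V member 1 (Rattus norvegicus) (a higher number here means a weaker inhibitor, a lower number a stronger inhibitor), compound 1 gives 105 nM.
Compound 2, `CC(C(=O)NCc1ccc(Cl)cc1)c1ccc(NS(C)(=O)=O)c(F)c1`; in this assay compound 2 gives 1060 nM.
Compound 3, `CC(C(=O)NCc1ccc(Cl)c(Cl)c1)c1ccc(NS(C)(=O)=O)c(F)c1`; in this assay compound 3 gives 200 nM.

Compound 3 holds the second highest of the three numbers. Compound 1 sits within the scatter of it, so the two cannot be told apart, while compound 2 lies beyond the scatter above it. For the measured compounds named here, the one measured step that bears on the next change is a 5.3-fold lower number from compound 2 to compound 3 (0.72 log units; beyond the scatter), a chloro in place of hydrogen on an aromatic carbon.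

Compound 4, `Cc1ccc(CNC(=O)C(C)c2ccc(NS(C)(=O)=O)c(F)c2)cc1`, differs from compound 3 by 4-methylphenyl in place of 3,4-dichlorophenyl on a saturated chain carbon bound to an amide-type nitrogen. This change does two things at once: it removes the chlorine that separates compound 3 from compound 2, and it swaps the remaining chlorine for a methyl. The second part has no measured counterpart among these compounds. Because a 5.3-fold lower number from compound 2 to compound 3 (0.72 log units; beyond the scatter) shows the added chlorine lowering the number well beyond the scatter, its removal is expected to raise the number by roughly the same amount, with the methyl swap adding uncertainty rather than a clear direction. Compound 4 is therefore expected to give about 1000 nM in this assay, with a likely range from 350 nM to 3000 nM. This amounts to an expected 5.0-fold higher number from compound 3 to compound 4 (0.70 log units; beyond the scatter).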

Compound 4, inhibition constant: 3100 nM
Estimate against measurement, compound 4: 3.1-fold (0.49 log units) below; the whole stated range lies below it.
By their numbers in this assay, from the lowest: compounds 1 and 3 (each within the scatter of the next); then compound 2; then compound 4.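

In this assay, the swap of 3,4-dichlorophenyl for 4-methylphenyl gives a 16-fold higher number from compound 3 to compound 4 (1.19 log units; beyond the scatter), a large loss that moves the new compound past both compounds with the same amide-linked side. The single-place comparison separates out the methyl: methyl in place of chloro on the aromatic carbon gives a 2.9-fold higher number from compound 2 to compound 4 (0.47 log units; beyond the scatter), so at this position methyl does not stand in for chloro, and the number rises even with the ring otherwise unchanged. Nothing shown explains why either chloro or methyl has this effect on the number.

For the compounds shown here, it remains open how a plain phenyl ring with no group at all would compare, and so whether the single chloro lowers the number or the methyl raises it, or both. From the compounds shown here alone, it is also open whether a ring carrying two methyl groups would regain ground as the second chlorine did, and where a ring carrying trifluoromethyl or methoxy in place of the methyl would fall.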